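Cyclohexyl Gives Way to 4-(Trifluoromethyl)phenyl in Compound 4

The compounds below may be only part of what the source reports. "The series", "measured", "known", "first", "only" and "open" are said of these compounds alone.

In a functional assay (plasma) for inhibition, with Homo sapiens as the target (on this read-out lower numbers stand for stronger inhibition and higher numbers for weaker inhibition), compound 3 (`Cc1ccc(S(=O)(=O)N[C@H]2CC/C(=N\OCC3CCCCC3)[C@@H]2C/C=C\CCCC(=O)O)cc1`) gives 600 nM and stands in the middle of the three measured compounds. Compound 2 (`O=C(O)CCC/C=C\C[C@H]1/C(=N/OCc2ccc(C(F)(F)F)cc2)CC[C@@H]1NS(=O)(=O)c1ccc(Cl)cc1`) reads lower (200 nM) and compound 1 (`O=C(O)CCC/C=C\C[C@H]1/C(=N/OC(c2ccccc2)c2ccccc2)CC[C@@H]1NS(=O)(=O)c1ccc(F)cc1`) reads much higher (17000 nM), both gaps lying beyond the scatter. Compound 4 (`Cc1ccc(S(=O)(=O)N[C@H]2CC/C(=N\OCc3ccc(C(F)(F)F)cc3)[C@@H]2C/C=C\CCCC(=O)O)cc1`) differs from compound 3 in one place (4-(trifluoromethyl)phenyl in place of cyclohexyl on a saturated chain carbon bound to an oxygen): 4-(trifluoromethyl)phenyl in place of cyclohexyl on a saturated chain carbon bound to an oxygen. Among the measured compounds shown here, no measured pair isolates this change. Compound 2 (200 nM) also carries 4-(trifluoromethyl)phenyl, so a modest move toward lower numbers in this assay is expected. The expected step is a 2.4-fold lower number from compound 3 to compound 4 (0.38 log units; beyond the scatter) and remains uncertain. Compound 4 is estimated at 250 nM within an expected range of 80 nM to 800 nM as the likely span.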

Compound 4, half-maximal inhibitory concentration: 180 nM
For compound 4 the middle estimate is 1.4-fold (0.14 log units) above the measured one; the measured number falls inside the stated range.
By their numbers in this assay, from the lowest: compounds 4 and 2 (each within the scatter of the next); then compound 3; then compound 1.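

Among the compounds shown here, for the first time, a pair isolates the change at this position: in this assay, 4-(trifluoromethyl)phenyl in place of cyclohexyl gives a 3.3-fold lower number from compound 3 to compound 4 (0.52 log units; beyond the scatter). With 4-(trifluoromethyl)phenyl kept, methyl in place of chloro on an aromatic carbon gives a 1.1-fold lower number from compound 2 to compound 4 (0.05 log units; within the scatter), so this assay does not separate those two groups in this pair. No available evidence bears on these steps. On these data alone, it remains open how a pyridyl group or a longer chain would read on that saturated carbon. As far as these compounds go, it is also open whether the step away from cyclohexyl holds with chloro on the aromatic carbon.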